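Weaker Binding Expected With An Oxanylmethyl Chain

A few compounds are considered here, and "the series" means these few. Any claim that something is new, unique, unknown or untested is made for them only; others in the source may bear on it.

Compound 3, `CO[C@H]1CC[C@@H](Nc2cc(NCc3cnccc3C(F)(F)F)ncc2C#N)CC1`, gives 5000 nM in an assay on isolated protein for inhibition of protein kinase C delta type (Homo sapiens), read by TR-FRET, with a stated time of 2 h; a lower number here means a stronger inhibitor, a higher number a weaker inhibitor. Two other compounds share its core. Compound 2, `N#Cc1cnc(NCc2ccccc2C(F)(F)F)cc1N[C@H]1CC[C@@H](O)CC1`, gives 4500 nM in this assay, and this lies within the usual scatter of the number for compound 3. Compound 1, `N#Cc1cnc(NCc2cnccc2C(F)(F)F)cc1NC[C@H]1C[C@H](O)C1`, gives only a limit of the assay, > 10000 nM, and no number.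

Compound 4, `N#Cc1cnc(NCc2cnccc2C(F)(F)F)cc1NCC1CCOCC1`, differs from compound 3 by (oxan-4-yl)methyl in place of 4-methoxycyclohexyl on a nitrogen on an aromatic ring. For the measured compounds named here, one measured step touches the same nitrogen: an at least 2.0-fold lower number from compound 1 to compound 3 (0.30 log units; that floor lies within the scatter), a step whose floor stems from the limit described as the limit of > 10000 nM in this assay, at which 1 of the 3 values shown sits. That step ran from a hydroxycyclobutylmethyl chain to a cyclohexyl ring bound straight to the nitrogen; the present change goes back to a one-carbon link between the nitrogen and a saturated ring, this time an oxane. Compound 1 sitting at a limit with such a link suggests that compound 4 is expected to bind no more tightly than compound 3, and possibly to reach a limit again. The expected step is a 1.6-fold higher number from compound 3 to compound 4 (0.20 log units; within the scatter), toward a higher number. Compound 4 is therefore estimated at 8000 nM in this assay, with a range from 3000 nM to 20000 nM.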

Compound 4, half-maximal inhibitory concentration: 5000 nM
Estimate against measurement, compound 4: 1.6-fold (0.20 log units) above; the measured number falls inside the stated range.
By their numbers in this assay, from the lowest: compounds 2, 3 and 4 (each within the scatter of the next). At a limit, above all of these: compound 1.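

Placing (oxan-4-yl)methyl where 4-methoxycyclohexyl stood, on a nitrogen on an aromatic ring, gives no change at the digits printed from compound 3 to compound 4 (within the scatter), so in this assay this position accepts a saturated ring held on a one-carbon link as well as a ring bound straight to the nitrogen. Compound 1 also carries a one-carbon link, yet it gives only a limit of the assay, > 10000 nM, so the link alone does not account for that result. With the link kept, oxan-4-yl in place of 3-hydroxycyclobutyl gives an at least 2.0-fold lower number from compound 1 to compound 4 (0.30 log units; that floor lies within the scatter), and this figure is only a floor, which leaves the true size of the step unknown: the limit of > 10000 nM in this assay, at which 1 of the 4 values shown sits.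

The compounds shown leave open whether the oxygen of the oxane ring matters here, as a cyclohexylmethyl group or a piperidin-4-ylmethyl amine on the same nitrogen would test. They also leave open how a longer chain carrying the oxane ring on this nitrogen would read in this assay.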